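From 4-methylphenyl to 4-fluorophenyl

A few compounds are considered here, and "the series" means these few. Any claim that something is new, unique, unknown or untested is made for them only; others in the source may bear on it.

Among the measured compounds shown here, in a functional assay on MCF7 cells (Homo sapiens) for antiproliferative activity, read by MTT assay, with a stated time of 24 h (on this read-out higher numbers stand for weaker inhibition and lower numbers for stronger inhibition), compound 1 (`Cc1ccc(-c2nn(-c3ccccc3)cc2-c2nc3ccccc3n2S(=O)(=O)c2ccccc2)cc1`) gives 830 nM, the lower of the two numbers so far, while compound 2 (`Cc1ccc(-c2nn(-c3ccccc3)cc2-c2nc3ccccc3n2S(=O)(=O)c2ccc(Cl)cc2)cc1`) gives 5930 nM. Compound 3 (`O=S(=O)(c1ccccc1)n1c(-c2cn(-c3ccccc3)nc2-c2ccc(F)cc2)nc2ccccc21`) has fluoro in place of methyl on an aromatic carbon, para to a large group: fluoro in place of methyl on an aromatic carbon. For the measured compounds named here, the only measured step, a 7.1-fold higher number from compound 1 to compound 2 (0.85 log units; beyond the scatter), is modest and puts chloro in place of hydrogen elsewhere, so it bears only loosely on this change. The expected step is likewise modest and towards a higher number: a 2.2-fold higher number from compound 1 to compound 3 (0.34 log units; beyond the scatter). The estimate for compound 3 is 1800 nM, with an expected range of 500 nM to 6000 nM.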

Compound 3, half-maximal inhibitory concentration: 690 nM
Estimate against measurement, compound 3: 2.6-fold (0.42 log units) above; the measured number falls inside the stated range.
By their numbers in this assay, from the lowest: compounds 3 and 1 (each within the scatter of the next); then compound 2.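

In this assay, fluoro in place of methyl on an aromatic carbon, para to a large group, gives a 1.2-fold lower number from compound 1 to compound 3 (0.08 log units; within the scatter), so the 4-methylphenyl and 4-fluorophenyl forms cannot be told apart on this read-out. This exchange therefore stays within the scatter, unlike the chloro step made elsewhere, a 7.1-fold higher number from compound 1 to compound 2 (0.85 log units; beyond the scatter). Nothing available explains why this position behaves this way.

The compounds shown leave open what an amine, a methoxy group or a carboxylic acid at this position would give. They also leave open whether the 4-fluorophenyl form would behave the same alongside the chloro group of compound 2.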